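The source may hold more compounds than are shown below. What is called first, only, known or untested is meant among the compounds shown, and "the series" means these compounds.

In a functional assay on KB cells (Homo sapiens) for cytotoxicity (on this read-out lower numbers stand for an effect already at smaller amounts and higher numbers for an effect only at larger amounts of compound), compound 1 `Clc1ccc2c(N/N=C/c3cnc[nH]3)ccnc2c1` gives 29.1 uM. Compound 3 `Clc1ccc2c(N/N=C/c3ccc(CN4CCCC4)cc3)ccnc2c1` gives 19.5 uM, within the scatter of compound 1, so these two cannot be separated on this read-out. Going by the values given here, compound 2 `Cn1cncc1/C=N/Nc1ccnc2cc(Cl)ccc12` gives 73.8 uM, and this is the only clear separation from compound 1 among the measured compounds.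

The next compound to consider is compound 4 `Cc1noc(C)c1/C=N/Nc1ccnc2cc(Cl)ccc12`, which keeps the core of compound 1 and changes the group on the carbon with a double bond to nitrogen: 3,5-dimethyl-1,2-oxazol-4-yl in place of 1H-imidazol-5-yl on a carbon with a double bond to nitrogen. In words, 3,5-dimethyl-1,2-oxazol-4-yl takes the place of 1H-imidazol-5-yl.

With only a 2.5-fold higher number from compound 1 to compound 2 (0.40 log units; beyond the scatter) as a guide, where methyl replaces hydrogen on an aromatic nitrogen, a modest step to a higher number is expected in this assay. Among the compounds with values here, that step is a smaller change than the one made here, and no measured compound in this set carries 3,5-dimethyl-1,2-oxazol-4-yl, so the expectation is loose.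

The estimated change is a 2.2-fold higher number from compound 1 to compound 4 (0.35 log units; beyond the scatter). For compound 4 the expected value is 65 uM, with an estimated range from 25 uM to 160 uM.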

Compound 4, concentration for half-maximal effect: 171 uM
Compound 4: the middle estimate sits 2.6-fold (0.42 log units) below what was measured; the measured number lies above the stated range.
By their numbers in this assay, from the lowest: compounds 3 and 1 (each within the scatter of the next); then compound 2; then compound 4.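

Keeping a five-membered aromatic ring with 2 hetero atoms on the carbon with a double bond to nitrogen does not by itself hold the level of compound 1 in this assay, since 3,5-dimethyl-1,2-oxazol-4-yl in place of 1H-imidazol-5-yl gives a 5.9-fold higher number from compound 1 to compound 4 (0.77 log units; beyond the scatter). Methylating the aromatic nitrogen did not mark the upper end of what this position can do to the read-out, as replacing 1-methyl-1H-imidazol-5-yl with 3,5-dimethyl-1,2-oxazol-4-yl gives a 2.3-fold higher number from compound 2 to compound 4 (0.36 log units; beyond the scatter). No measurement here accounts for the rise, so it stands as an observation on these compounds only.

From the compounds shown here alone, it remains open whether the ring itself or its two methyl groups carry the change, and the unsubstituted 1,2-oxazol-4-yl group would separate the two. Compound 3, which stays within the scatter of compound 1, leaves open whether other groups at this place, such as a phenyl ring bearing a carboxylic acid or a primary amine in place of the pyrrolidine, would also stay at that level.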